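A few compounds are considered here, and "the series" means these few. Any claim that something is new, unique, unknown or untested is made for them only; others in the source may bear on it.

The measured compounds and their numbers in an ADME assay on HeLa cells (Homo sapiens) for cytotoxicity, read by sulforhodamine B assay, with a stated time of 48 h, tested at 10 uM; on this read-out lower numbers stand for less inhibition and higher numbers for more inhibition at the one concentration tested (going by the name of the read-out):
Compound 1, `CCCCCCc1cn(C(c2ccccc2)c2cc3cc(Br)ccc3nc2OC)nn1`, gives -0.97%.
Compound 2, `COc1nc2ccc(Br)cc2cc1C(c1ccccc1)n1cc(-c2ccccc2)nn1`, gives 13.9%.
Compound 3, `COc1nc2ccc(Br)cc2cc1C(c1ccccc1)n1cc(CCO)nn1`, gives 0.85%.

Compound 3 stands second highest of the three, but its number lies within the scatter of compound 1, so those two cannot be told apart; only compound 2 stands clearly higher, as the step of a number 13.1 percentage points lower from compound 2 to compound 3 (beyond the scatter) shows. Compound 4, `COc1nc2ccc(Br)cc2cc1C(c1ccccc1)n1cc(-c2ccc(F)cc2)nn1`, has not yet been measured. It differs from compound 3 at the five-membered aromatic ring with 3 nitrogen: 4-fluorophenyl in place of 2-hydroxyethyl on an aromatic carbon.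

Going by the values given here, two measured steps bear on this change. The step of a number 13.1 percentage points lower from compound 2 to compound 3 (beyond the scatter) shows what happens when phenyl on that ring carbon is exchanged for 2-hydroxyethyl, and the step of a number 14.9 percentage points higher from compound 1 to compound 2 (beyond the scatter) shows phenyl entering in place of hexyl. Among these three compounds both point the same way: an aromatic ring on that carbon goes with a modestly higher number than a chain. Compound 4 carries 4-fluorophenyl, close kin to phenyl, so the step from compound 3 is expected to be roughly the reverse of the first of these, about a number 12.2 percentage points higher from compound 3 to compound 4 (beyond the scatter), upward and beyond the scatter. For compound 4 the estimated value in this assay is 13%, with a range from -2% to 28%. Among the compounds with values here, the fluorine has no measured counterpart here, which widens the range.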

Compound 4, a percentage reported as inhibition, at one concentration (the size of the read-out at that concentration, not a potency): 4.27%
The estimate for compound 4 lay 8.7 percentage points above the measured number; the range from low to high includes it.
By their numbers in this assay, from the lowest: compounds 1, 3, 4 and 2 (each within the scatter of the next, the first and the last beyond it).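

In this assay, going by these compounds alone, the earlier steps suggested that an aromatic ring on this carbon of the five-membered ring goes with a clearly higher number than a chain, but 4-fluorophenyl in place of 2-hydroxyethyl gives no such separation (a number 3.4 percentage points higher from compound 3 to compound 4 (within the scatter)), and neither does 4-fluorophenyl in place of hexyl (a number 5.2 percentage points higher from compound 1 to compound 4 (within the scatter)). Fluoro in place of hydrogen on the phenyl ring also stays inside the usual scatter (a number 9.6 percentage points lower from compound 2 to compound 4 (within the scatter)), so compound 4 cannot be told apart from compound 2 either, even though compound 2 does stand clear of compound 1 and compound 3. Having an aromatic ring at this position is therefore not enough on its own to give a clear separation from the chains: compound 2 fits that earlier pattern, while compound 4 goes against it.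

No measurement shown here offers an explanation for this result. From the compounds shown here alone, it also remains open how this read-out would respond to an aminomethyl group, a carboxylic acid or a longer chain ending in an amine on the same carbon, or to a chloro or methoxy group in place of the fluoro on the phenyl ring.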